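A few compounds are considered here, and "the series" means these few. Any claim that something is new, unique, unknown or untested is made for them only; others in the source may bear on it.

In a functional assay on ASPC1 cells (Homo sapiens) for antiproliferative activity, read by sulforhodamine B assay, with a stated time of 48 h (a lower number here means a stronger inhibitor, a higher number a weaker inhibitor), compound 1 `O=C(CCCCCCN1C(=O)/C(=N\O)c2cc(Cl)ccc21)NO` gives 1860 nM and compound 2 `O=C(CCCCCCN1C(=O)/C(=N\O)c2cc(Br)ccc21)NO` gives 80 nM on the same core. Compound 3 `O=C(CCCCCCN1C(=O)/C(=N\O)c2cc([N+](=O)[O-])ccc21)NO` gives 4680 nM as the highest number of the three. Compound 4 `Cc1ccc2c(c1)/C(=N/O)C(=O)N2CCCCCCC(=O)NO` is still unmeasured and differs from compound 3 by methyl in place of nitro on an aromatic carbon in one swap, methyl in place of nitro on an aromatic carbon. Swaps at this same place have moved the number widely: the step of a 2.5-fold higher number from compound 1 to compound 3 (0.40 log units; beyond the scatter) is modest, while a 59-fold higher number from compound 2 to compound 3 (1.77 log units; beyond the scatter) and a 23-fold lower number from compound 1 to compound 2 (1.37 log units; beyond the scatter) are both large. Going by the values given here, no methyl compound has been measured, so the size stays uncertain. With compound 3 at 4680 nM as the top value, a clear fall in this assay is expected, an estimated 5.2-fold lower number from compound 3 to compound 4 (0.72 log units; beyond the scatter) in all. Compound 4 is estimated at 900 nM with a range of 150 nM to 4000 nM for the measurement.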

Compound 4, half-maximal inhibitory concentration: 2440 nM
For compound 4 the middle estimate is 2.7-fold (0.43 log units) below the measured one; low and high end bracket the measured number.
By their numbers in this assay, from the lowest: compound 2; then compounds 1, 4 and 3 (each within the scatter of the next, the first and the last beyond it).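

In this assay methyl at this position falls in with chloro and nitro: both a 1.9-fold lower number from compound 3 to compound 4 (0.28 log units; within the scatter) and a 1.3-fold higher number from compound 1 to compound 4 (0.12 log units; within the scatter) stay within the usual scatter, while a 31-fold higher number from compound 2 to compound 4 (1.48 log units; beyond the scatter) is large. Bromo in compound 2 therefore stands apart from all three other groups at this place on the aromatic ring, not just from chloro and nitro. No measured evidence here explains this gap. The compounds shown leave open whether iodo or an amine at this place would match bromo or group with the other three. They also leave open whether bromo keeps its lead with a longer chain.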